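The compounds below may be only part of what the source reports. "The series", "measured", "known", "first", "only" and "open" are said of these compounds alone.

Among the measured compounds shown here, compound 1 `O=C(O)C[C@@H]1CCCN1c1ccc(Oc2ccccc2)cc1` gives 560 nM in a functional assay on cells for agonist activity at Free fatty acid receptor 1 (Homo sapiens), read by FLIPR and calcium flux, with a stated time of 100 s (on this read-out higher numbers stand for an effect only at larger amounts of compound and lower numbers for an effect already at smaller amounts), the lowest of the two numbers measured so far. For the measured compounds named here, compound 2 `O=C(O)C[C@@H]1CCCN1c1ccc(Oc2ccccc2-c2ccccc2)cc1` gives 3500 nM in this assay, and the step of a 6.3-fold higher number from compound 1 to compound 2 (0.80 log units; beyond the scatter) is the only measured change on an aromatic carbon of that kind. Going by the values given here, compound 3 `CN(C)c1cccc(Oc2ccc(N3CCC[C@H]3CC(=O)O)cc2)c1` carries dimethylamino in place of hydrogen on an aromatic carbon, a group unlike the one that entered in compound 2. Among the compounds with values here, because a 6.3-fold higher number from compound 1 to compound 2 (0.80 log units; beyond the scatter) is the sole guide and points toward a weaker response, the expected value for compound 3 in this assay is 900 nM, with a range from 250 nM to 3000 nM, which amounts to an expected step of a 1.6-fold higher number from compound 1 to compound 3 (0.21 log units; within the scatter).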

Compound 3, half-maximal effective concentration: 1300 nM
Compound 3: the middle estimate sits 1.4-fold (0.16 log units) below what was measured; low and high end bracket the measured number.
By their numbers in this assay, from the lowest: compound 1; then compound 3; then compound 2.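

In this assay, dimethylamino in place of hydrogen on an aromatic carbon, meta to a large group, gives a 2.3-fold higher number from compound 1 to compound 3 (0.37 log units; beyond the scatter). Among the compounds shown here, a group with no ring thus also raises the number, so the phenyl of compound 2 is not the only entering group that does so, and compound 1 keeps the lowest value of the three. Nothing available bears on the reason for this step.

Going by these compounds, whether a methoxy group or a fluorine atom on this same carbon would leave the number unchanged or lower it remains open. So does the effect of dimethylamino on another aromatic carbon of that ring.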